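The source may hold more compounds than are shown below. What is called first, only, known or untested is meant among the compounds shown, and "the series" means these compounds.

Compound 1 `O=C(Nc1cc(-c2ccccc2)nn1-c1ccccc1)c1ccccc1`: 203 nM
Compound 2 `O=C(Nc1cc(-c2ccccc2)nn1-c1ccccc1)c1cccc(C(F)(F)F)c1`: 228 nM
Compound 3 `O=C(Nc1cc(-c2ccccc2)nn1-c1ccccc1)c1cccc([N+](=O)[O-])c1`: 39 nM

In a functional assay on cells for positive allosteric modulation of metabotropic glutamate receptor 5 (Rattus norvegicus), read by calcium flux (a higher number here means that more compound is needed for the effect, a lower number that less compound is needed), compound 1 gives 203 nM, the second highest of the three numbers. Compound 2 lies close to it, a 1.1-fold higher number from compound 1 to compound 2 (0.05 log units; within the scatter), whereas compound 3 lies well apart, a 5.2-fold lower number from compound 1 to compound 3 (0.72 log units; beyond the scatter). Compound 4 `O=C(Nc1cc(-c2ccccc2)nn1-c1cccc(Br)c1)c1ccccc1` differs from compound 1 by bromo in place of hydrogen on an aromatic carbon. Going by the values given here, none of the measured steps bears directly on this change: the step from compound 1 to compound 2, the step from compound 1 to compound 3 and the step from compound 2 to compound 3 (a 5.8-fold lower number from compound 2 to compound 3 (0.77 log units; beyond the scatter)) all alter a different part of the molecule, and none of them swaps hydrogen for bromo. Among the compounds with values here, with no direct precedent, a step of a 1.0-fold lower number from compound 1 to compound 4 (0.01 log units; within the scatter) within the scatter is expected. Compound 4 is therefore estimated at 200 nM, with a range from 60 nM to 700 nM.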

Compound 4, half-maximal effective concentration: 400 nM
Compound 4: middle estimate off by 2.0-fold (0.30 log units), on the low side; the range from low to high includes it.
By their numbers in this assay, from the lowest: compound 3; then compounds 1, 2 and 4 (each within the scatter of the next).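

In this assay, going by these compounds alone, adding bromo to this ring, a different part of the molecule from the one altered in compounds 2 and 3, gives a 2.0-fold higher number from compound 1 to compound 4 (0.29 log units; within the scatter). Replacing phenyl with 3-bromophenyl therefore leaves the number within the usual scatter, so this position can carry a single bromine atom without a clear loss or gain. Nothing available explains this result. Still open, from the compounds shown here alone, is whether nitro at this position would lower the number, as it did on the other ring in compound 3. An amine or a carboxylic acid here could also behave differently from bromo.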